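A Methoxyphenyl for a Fluorophenyl: Expecting Compound 3

The compounds below may be only part of what the source reports. "The series", "measured", "known", "first", "only" and "open" are said of these compounds alone.

Compound 2 `CC(C)n1ncc2c(C(=O)NCc3cn(-c4cccc(F)c4)nn3)cccc21` is one of two compounds tested in a functional assay on PC-3 cells (Homo sapiens) for inhibition, read by MTT assay, with a stated time of 72 h (a lower number here means a stronger inhibitor, a higher number a weaker inhibitor), where compound 2 gives 36100 nM. That is the higher of the two numbers. The other, compound 1 `CC(C)n1ncc2c(C(=O)Nc3ccccc3)cccc21`, gives 11900 nM in this assay, a lower figure by a margin beyond the usual scatter. Compound 3 `COc1ccc(-n2cc(CNC(=O)c3cccc4c3cnn4C(C)C)nn2)cc1` has not been measured. It differs from compound 2 in one place: 4-methoxyphenyl in place of 3-fluorophenyl on an aromatic nitrogen. Among the measured compounds shown here, no measured pair shows what such a swap does, so no direction can be read from the data. The step of a 1.2-fold lower number from compound 2 to compound 3 (0.08 log units; within the scatter) is therefore expected to stay within the scatter. Compound 3 is estimated at 30000 nM, within 12000 nM to 90000 nM.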

Compound 3, half-maximal inhibitory concentration: 34300 nM
Compound 3: the middle estimate sits 1.1-fold (0.06 log units) below what was measured, and the stated range covers the measured number.
By their numbers in this assay, from the lowest: compound 1; then compounds 3 and 2 (each within the scatter of the next).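

In this assay, putting 4-methoxyphenyl in place of 3-fluorophenyl on the aromatic nitrogen gives a 1.1-fold lower number from compound 2 to compound 3 (0.02 log units; within the scatter), so the two compounds cannot be told apart. At this position, then, this exchange of one substituted phenyl ring for another, with a hydrogen-bond acceptor counted only in the entering group, leaves no readable difference. Nothing available explains why the two compounds read alike. The compounds shown leave open what a phenyl ring bearing an amine or a carboxylic acid would give here. They also leave open what a plain alkyl chain would give in place of the ring.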